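This account rests on a few compounds, and the source may have more. Where it says the series, first, only, none or still open, it means among the compounds named here.

Measured so far: compound 1 `O=C(/C=C1\CCc2ccc(F)cc21)NCC1CC1` gives 21%; compound 2 `NC(=O)/C=C1\CCc2cc(F)cc(F)c21` gives 55%; compound 3 `COc1ccc2c(c1)/C(=C/C(N)=O)CC2` gives 3%.

All three numbers come from a functional assay on the whole organism with Rattus norvegicus as the target, at a dose of 20 mg/kg by the oral route; on this read-out lower numbers stand for less inhibition and higher numbers for more inhibition at the one dose given (going by the name of the read-out). Among them compound 2 stands highest: its nearest neighbour is compound 1, whose number lies beyond the scatter below it, and the furthest is compound 3, whose number lies further still below it, also beyond the scatter. Compound 1 and compound 3 carry a different amide and a different ring substituent, so their two values only show that both fall well short of compound 2 in this assay.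

The next compound, compound 4 `NC(=O)/C=C1\CCc2cc(F)ccc21`, keeps the primary amide of compound 2 and differs from it in one place: hydrogen in place of fluoro on an aromatic carbon. Going by the values given here, no measured pair shows this exact change, so its effect is unknown from the data. Because compound 2 gives 55% while compound 1, which carries a single fluoro on the shared core, gives 21%, a downward step is expected in this assay, of a size beyond the scatter, though a smaller drop would not surprise. The estimate for compound 4 is therefore 30%, with a range from 5% to 58%, which corresponds to an expected step of a number 25 percentage points lower from compound 2 to compound 4 (beyond the scatter).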

Compound 4, a percentage reported as inhibition, in the whole organism at one dose (the size of the read-out at that dose, not a potency): 42%
The estimate for compound 4 lay 12 percentage points below the measured number; the measured number falls inside the stated range.
By their numbers in this assay, from the lowest: compound 3; then compound 1; then compound 4; then compound 2.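

In this assay, going by these compounds alone, this is the first step that isolates a single change, and it concerns the fluoro on an aromatic carbon ortho to a fused ring: hydrogen in its place gives a number 13 percentage points lower from compound 2 to compound 4 (beyond the scatter). The read-out therefore depends measurably on this position, yet it does not rest on this fluoro alone, since compound 4, which has hydrogen there and keeps the other fluoro, still gives 42%. No measurement here offers an explanation for the step.

The compounds shown leave open whether a chloro, a methyl or an amine at this aromatic carbon would match the fluoro of compound 2, fall towards the hydrogen of compound 4 or go beyond either. They also leave open what removing the remaining fluoro would do on its own, and whether a step of this size would persist at another dose or with an amide other than the primary one.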